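The source may report more compounds than this note shows. Statements on the series, on what has been measured and on what is new or still open speak of the compounds shown alone.

Measured compounds:
- compound 1, `O=C(CSc1nnc(-c2ccncc2)o1)N/N=C/c1ccc(F)cc1`, 12300 nM in a functional assay on HepG2 cells (Homo sapiens) for cytotoxicity, read by MTT assay, with a stated time of 48 h; on this read-out higher numbers stand for weaker inhibition and lower numbers for stronger inhibition
- compound 2, `O=C(CSc1nnc(-c2ccncc2)o1)N/N=C/c1ccc(O)cc1`, 5510 nM in this assay
- compound 3, `O=C(CSc1nnc(-c2ccncc2)o1)N/N=C/c1ccccc1[N+](=O)[O-]`, 24700 nM in this assay

Compound 2 gives the lowest number of the three, so it is the strongest inhibitor of this set, and both of its neighbours lie beyond the scatter. Compound 4, `O=C(CSc1nnc(-c2ccncc2)o1)N/N=C/C=C/c1ccccc1`, differs from it by 2-phenylethenyl in place of 4-hydroxyphenyl on a carbon with a double bond to nitrogen, so the hydrogen-bond donor and the hydrogen-bond acceptor leave and a double bond outside aromatic rings enters. Among the compounds with values here, two measured steps touch the same position: a 2.2-fold lower number from compound 1 to compound 2 (0.35 log units; beyond the scatter) and a 4.5-fold higher number from compound 2 to compound 3 (0.65 log units; beyond the scatter). In both, the compound lacking the hydroxy has the higher number. The step in this assay from compound 2 to compound 4 is therefore expected to be upward, estimated as a 2.2-fold higher number from compound 2 to compound 4 (0.34 log units; beyond the scatter). Compound 4 is expected to give 12000 nM in this assay, within 5000 nM to 30000 nM.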

Compound 4, half-maximal inhibitory concentration: 7420 nM
Beside the measured number, compound 4's estimate is 1.6-fold (0.21 log units) above it; the measured number falls inside the stated range.
By their numbers in this assay, from the lowest: compounds 2, 4, 1 and 3 (each within the scatter of the next, the first and the last beyond it).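

The earlier compounds suggested that losing the hydroxy raises the number, but compound 4 goes against that: with no hydrogen-bond donor, it shows a 1.3-fold higher number from compound 2 to compound 4 (0.13 log units; within the scatter), so among these compounds a hydroxy is not needed to stay within the scatter of compound 2. The 2-phenylethenyl group also gives a 1.7-fold lower number from compound 1 to compound 4 (0.22 log units; within the scatter) and a 3.3-fold lower number from compound 3 to compound 4 (0.52 log units; beyond the scatter), so only compound 3 stands clearly apart from compound 4. Nothing available explains these numbers. Still open, from the compounds shown here alone, is whether a 4-aminophenyl group or a longer chain ending in phenyl would keep the number at this level.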